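Replacing the Methoxyphenyl Arm of a Weak Vinyl Sulfone

This account rests on a few compounds, and the source may have more. Where it says the series, first, only, none or still open, it means among the compounds named here.

This account follows three vinyl sulfones measured in a functional assay on DU-145 cells (Homo sapiens) for inhibition, read by trypan blue exclusion, with a stated time of 96 h (on this read-out lower numbers stand for stronger inhibition of growth and higher numbers for weaker inhibition of growth), and asks what a fourth might show. Compound 1, `COc1ccc(/C=C(\C(=O)c2ccc(Br)cc2)S(=O)(=O)c2ccc(Br)cc2)cc1`, gives 25000 nM in this assay, the highest of the three numbers and therefore the weakest inhibitor among them. Compound 2, `COc1ccc(/C=C(\C(=O)c2ccc(Cl)cc2)S(=O)(=O)c2ccc(Br)cc2)cc1`, gives 10000 nM, and the step of a 2.5-fold lower number from compound 1 to compound 2 (0.40 log units; beyond the scatter) is modest. Compound 3, `COc1ccc(/C=C(\C(=O)c2ccc(Br)cc2)S(=O)(=O)c2ccc(C)cc2)cc1`, gives 1000 nM, and the step of a 25-fold lower number from compound 1 to compound 3 (1.40 log units; beyond the scatter) is large. Both measured steps alter a substituent on one of the two aryl rings attached through the carbonyl or the sulfonyl group; neither touches the arm that carries the 4-methoxyphenyl group.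

Compound 4, `O=C(/C(=C\c1c[nH]c2ccccc12)S(=O)(=O)c1ccc(Br)cc1)c1ccc(Br)cc1`, differs from compound 1 in exactly that untouched arm: 1H-indol-3-yl in place of 4-methoxyphenyl on a double-bonded chain carbon bound to a double-bonded chain carbon. Among the compounds with values here, no measured step bears on a change at this position, so the two steps above give no direction to borrow. The expectation for compound 4 is therefore a step of a 1.7-fold lower number from compound 1 to compound 4 (0.22 log units; within the scatter), essentially none beyond the scatter, with a wide range to reflect the absence of any guiding precedent. Compound 4 is thus estimated at 15000 nM in this assay, within 3000 nM to 60000 nM.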

Compound 4, concentration for 50% growth inhibition: 25000 nM
The estimate for compound 4 lay 1.7-fold (0.22 log units) below the measured number, and the stated range covers the measured number.
By their numbers in this assay, from the lowest: compound 3; then compound 2; then compounds 1 and 4 (each within the scatter of the next).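

In this assay, within the data shown here, putting 1H-indol-3-yl in place of 4-methoxyphenyl on a double-bonded chain carbon bound to a double-bonded chain carbon gives no change at the digits printed from compound 1 to compound 4 (within the scatter), the first reading at this position, which until now had only the two aryl substituent steps beside it. With both bromo groups held constant, the read-out does not separate the two arms, even though the entering group brings a five-membered aromatic ring and a hydrogen-bond donor and the leaving group takes a hydrogen-bond acceptor with it. No measured property of either group is available to account for this result.

The compounds shown leave open whether the 1H-indol-3-yl arm would read the same on the core of compound 3, which carries methyl where compound 1 carries a bromo group on the sulfonyl-bound ring, and so whether this result holds beyond the dibromo pair. They also leave open whether an arm of a different kind at this place, such as a phenyl ring bearing an amine or a carboxylic acid, would separate from 4-methoxyphenyl in this assay.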